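Removing a hydroxyphenyl tail from an inactive glycoside ester

The source may report more compounds than this note shows. Statements on the series, on what has been measured and on what is new or still open speak of the compounds shown alone.

Measured compounds, with values in a functional assay on SK-BR-3 cells (Homo sapiens) for antiproliferative activity, read by MTT assay, with a stated time of 72 h; on this read-out lower numbers stand for stronger inhibition and higher numbers for weaker inhibition:
compound 1 `C=C(C)CCOC(=O)C[C@@H]1C(C(=O)OC)=CO[C@@H](O[C@@H]2O[C@H](CO)[C@@H](O)[C@H](O)[C@H]2O)/C1=C/C` — limit, > 15000 nM
compound 2 `C/C=C1/[C@H](O[C@@H]2O[C@H](CO)[C@@H](O)[C@H](O)[C@H]2O)OC=C(C(=O)OC)[C@H]1CC(=O)OCCc1ccc(O)cc1` — limit, > 20000 nM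
compound 3 `C/C=C1/[C@H](O[C@@H]2O[C@H](COC(C)=O)[C@@H](OC(C)=O)[C@H](OC(C)=O)[C@H]2OC(C)=O)OC=C(C(=O)O)[C@H]1CC(=O)OC` — limit, > 20000 nM

All three values are limits of this assay, not numbers. Compound 2 sits at the limit described by the limit of > 20000 nM in this assay, at which 2 of the 3 values shown sit, alongside compound 3, while compound 1 sits at the limit of > 15000 nM in this assay, at which 1 of the 3 values shown sits. The step that the two limits leave unreadable from compound 1 to compound 2 cannot be read for size because both ends are limits.

Compound 4 `C/C=C1/[C@H](O[C@@H]2O[C@H](CO)[C@@H](O)[C@H](O)[C@H]2O)OC=C(C(=O)OC)[C@H]1CC(=O)OCC` differs from compound 2 by hydrogen in place of 4-hydroxyphenyl on a saturated chain carbon, two bonds along the chain from an oxygen next to a carbonyl group. Among the measured compounds shown here, no measured step with readable size bears on this change. Since compound 2 and all related compounds give only limits, compound 4 is expected to remain at a limit, with a step that the limit leaves unreadable from compound 2 to compound 4 expected to be no readable step. Compound 4 is estimated at 30000 nM, in the range 15000 nM to 100000 nM.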

Compound 4, half-maximal inhibitory concentration: > 15000 nM
Compound 4: only a limit was reported; the forecaster's own chance of this, stated with the estimate: 90%; the middle value lies beyond the limit too.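

Compound 1, compound 2 and compound 4 all give only limits in this assay, and the steps from compound 2 to compound 4 and from compound 1 to compound 4 cannot be read for size. The compounds shown leave open whether any change to the ester chain on the shared core would give a measurable value.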